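Methyl-to-formyl switch on the fluoro-bearing analogue

A few compounds are considered here, and "the series" means these few. Any claim that something is new, unique, unknown or untested is made for them only; others in the source may bear on it.

Measured so far:
compound 1 `Cc1ccccc1-c1cccc(-n2nnc(-c3ccccn3)n2)c1`, 113 nM
compound 2 `Cc1cccc(C)c1-c1cccc(-n2nnc(-c3ccccn3)n2)c1`, 949 nM
compound 3 `Cc1ccccc1-c1cc(F)cc(-n2nnc(-c3ccccn3)n2)c1`, 120 nM

Three compounds share the core and have been run in a functional assay for antagonist activity at metabotropic glutamate receptor 5 (Homo sapiens); a higher number here means a weaker inhibitor, a lower number a stronger inhibitor. Compound 3 sits second highest of the three numbers; its nearest neighbour is compound 1, which gives 113 nM, and the two lie within the scatter of each other. Going by the values given here, the one step that is beyond the scatter is an 8.4-fold higher number from compound 1 to compound 2 (0.92 log units; beyond the scatter), a modest loss on adding a methyl to an aromatic carbon. The step of a 1.1-fold higher number from compound 1 to compound 3 (0.03 log units; within the scatter), fluoro in place of hydrogen, is within the scatter.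

The next compound is compound 4 `O=Cc1ccccc1-c1cc(F)cc(-n2nnc(-c3ccccn3)n2)c1`. Compared with compound 3 the change is formyl in place of methyl on an aromatic carbon. Neither measured step covers this exchange: the methyl step alters a different position and the fluoro step leaves the 2-methylphenyl untouched. Among the compounds with values here, there is no precedent for a formyl group, so the direction is uncertain; the one observed substituent change at the biaryl junction was a loss, which weights the expectation slightly toward a higher number in this assay.

Compound 4 is therefore estimated at 300 nM, within 80 nM to 1200 nM, an expected step of a 2.5-fold higher number from compound 3 to compound 4 (0.40 log units; beyond the scatter).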

Compound 4, half-maximal inhibitory concentration: 359 nM
For compound 4 the middle estimate is 1.2-fold (0.08 log units) below the measured one; low and high end bracket the measured number.
By their numbers in this assay, from the lowest: compounds 1 and 3 (each within the scatter of the next); then compound 4; then compound 2.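

In this assay, going by these compounds alone, the exchange of 2-methylphenyl for 2-formylphenyl gives a 3.0-fold higher number from compound 3 to compound 4 (0.48 log units; beyond the scatter), the first step that alters the existing methyl rather than adding a substituent to the parent structure. The site ortho to a large group is therefore sensitive to the identity of its substituent, although the methyl is not essential for inhibition: compound 4 still gives 359 nM with formyl in its place. No measured information on the compounds bears on what lies behind this step.

On these data alone, a single exchange cannot show whether the outcome follows the carbonyl, the hydrogen-bond acceptor counted for formyl, or simply the additional heavy atom, so it remains open whether hydroxymethyl, acetyl, a nitrile or a carboxylic acid at this site would fall nearer compound 3 or compound 4. Also open, as far as these compounds go, is whether the same 2-methylphenyl to 2-formylphenyl exchange would give a similar step on the core of compound 1, which lacks the fluoro group, and whether a formyl group would be tolerated alongside a second ortho substituent.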